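A small fluoro swap on compound 2

A few compounds are considered here, and "the series" means these few. Any claim that something is new, unique, unknown or untested is made for them only; others in the source may bear on it.

Compound 1 `CC(=O)N[C@@H]1CCC[C@H](C(=O)Nc2cc(-c3cnc(C)n3C(C)C)ccn2)C1` gives 1.9
Compound 2 `CC(=O)N[C@@H]1CCC[C@H](C(=O)Nc2cc(-c3cnn4c3CCCC4)ccn2)C1` gives 2.4

Within the data shown here, in a physicochemical assay for lipophilicity, using the shake flask method, measured as octanol-water partition, at pH 7.4 (a higher number here means a more lipophilic compound, a lower number a more polar compound), compound 2 stands at 2.4 as the higher of the two numbers so far. Compound 3 `CC(=O)N[C@@H]1CCC[C@H](C(=O)Nc2cc(-c3cnn4c3CCCC4)c(F)cn2)C1` differs from it by a single change fluoro in place of hydrogen on an aromatic carbon that puts fluoro in place of hydrogen on an aromatic carbon. Among the measured compounds shown here, the only measured step is a number 0.50 log units higher from compound 1 to compound 2 (beyond the scatter) and it swaps one ring-bearing group for another, so it offers only a rough scale. For the measured compounds named here, no measured step covers fluoro. The expected step is small and upward, probably no larger than the scatter, and is estimated as a number 0.20 log units higher from compound 2 to compound 3 (within the scatter) in this assay here. For compound 3 the estimate is 2.6 with an expected range from 2.3 to 2.9 until a measurement arrives.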

Compound 3, distribution coefficient: 2.9
Compound 3: the middle estimate sits 0.30 log units below what was measured; measured number inside the range.
By their numbers in this assay, from the lowest: compound 1; then compound 2; then compound 3.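

In this assay, fluoro in place of hydrogen on an aromatic carbon, two atoms from the ring nitrogen, gives a number 0.50 log units higher from compound 2 to compound 3 (beyond the scatter). This single-atom change therefore moves the number as far as exchanging a whole ring-bearing group did, seen in a number 0.50 log units higher from compound 1 to compound 2 (beyond the scatter). Nothing measured here gives a reason for this rise at this position.

On these data alone, whether chloro, a nitrile or a methoxy group at the same place would shift the number similarly remains open, as does whether fluoro elsewhere on the ring would do the same.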